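The source may hold more compounds than are shown below. What is called first, only, known or untested is meant among the compounds shown, and "the series" means these compounds.

Measured in a functional assay on U-87MG ATCC cells for inhibition, with U-87 MG (Homo sapiens) as the target, read by MTT assay, with a stated time of 72 h; on this read-out higher numbers stand for weaker inhibition and lower numbers for stronger inhibition:
Compound 1 `Cc1ccnc(NC(c2ccc(F)cc2)c2ccc3cccnc3c2O)c1`: > 10000 nM, a limit of the assay and not a number.
Compound 2 `Cc1ccnc(NC(c2ccc3cccnc3c2O)c2c(F)cccc2Cl)c1`: 20600 nM.

Within the data shown here, compound 2 holds the only actual number, 20600 nM. Compound 3 `Cc1ccnc(NC(c2ccccc2C)c2ccc3cccnc3c2O)c1` carries 2-methylphenyl in place of 2-chloro-6-fluorophenyl, on a saturated chain carbon bound to an aromatic carbon and a nitrogen on an aromatic ring: 2-methylphenyl in place of 2-chloro-6-fluorophenyl on a saturated chain carbon bound to an aromatic carbon and a nitrogen on an aromatic ring. Among the measured compounds shown here, the one measured step at that place, a step that the limit leaves unreadable from compound 1 to compound 2, offers no size to carry over. The step expected is therefore a 1.4-fold lower number from compound 2 to compound 3 (0.14 log units; within the scatter), none beyond the scatter. Compound 3 is estimated at 15000 nM, with an expected range from 6000 nM to 35000 nM.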

Compound 3, half-maximal inhibitory concentration: > 10000 nM
Compound 3: a limit, no number (the forecaster's own chance of this, stated with the estimate: 40%); the middle value lies beyond the limit too.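

No step among compound 1, compound 2 and compound 3 can be read, because two of these values are limits and not numbers: the limit of > 10000 nM in this assay, at which 2 of the 3 values shown sit.

The compounds shown leave open how the actual values of compound 1 and compound 3 compare with that of compound 2.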